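Swapping a Small Amine for a Chlorophenoxy Arm

The source may hold more compounds than are shown below. What is called first, only, known or untested is meant among the compounds shown, and "the series" means these compounds.

Three nitrofuran amides have been tested in an ADME assay on Vero cells (Chlorocebus sabaeus) for cytotoxicity, read by MTT assay, with a stated time of 48 h; on this read-out higher numbers stand for lower toxicity in this test and lower numbers for higher toxicity in this test. Compound 1 `CC(NC(=O)c1ccc([N+](=O)[O-])o1)c1ccccc1` gives 24000 nM. Compound 2 `CN(C)c1ccc(C(C)(C)NC(=O)c2ccc([N+](=O)[O-])o2)cc1` gives 79000 nM, the highest of the three numbers and therefore the least toxic reading in this test; its gaps to compound 1 and to compound 3 both lie beyond the scatter. Compound 3 `O=C(NCc1ccc(Oc2ccc(Cl)cc2)cc1)c1ccc([N+](=O)[O-])o1` gives 8400 nM, the lowest of the three.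

Compound 4 `CC(C)(NC(=O)c1ccc([N+](=O)[O-])o1)c1ccc(COc2ccccc2Cl)cc1` has not yet been measured in this assay. It differs from compound 2 in one place: (2-chlorophenoxy)methyl in place of dimethylamino on an aromatic carbon The entering group sits on an aromatic carbon of a six-membered aromatic ring of carbon only, para to a large group.

Within the data shown here, no pair of measured compounds differing in a single place is available to anchor this change, so any expectation must rest on the spread of the three values. Compound 4 is expected to give a lower number than compound 2, toward the more toxic end, because compound 3 gives 8400 nM and is the measured compound whose makeup comes closest to compound 4. The step expected is a 5.3-fold lower number from compound 2 to compound 4 (0.72 log units; beyond the scatter), which would lie beyond the scatter. Compound 4 is estimated at 15000 nM, within a range from 5000 nM to 50000 nM.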

Compound 4, half-maximal cytotoxic concentration: 30000 nM
Estimate against measurement, compound 4: 2.0-fold (0.30 log units) below, and the stated range covers the measured number.
By their numbers in this assay, from the lowest: compound 3; then compounds 1 and 4 (each within the scatter of the next); then compound 2.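

In this assay, among these compounds, putting (2-chlorophenoxy)methyl in place of dimethylamino on the aromatic carbon gives a 2.6-fold lower number from compound 2 to compound 4 (0.42 log units; beyond the scatter), the first step here that can be tied to a single place in the structure. The entering group has 9 heavy atoms against 3 for the leaving group and adds a six-membered aromatic ring, yet the number shifts only modestly, though beyond the usual scatter, so this position can take a much larger group without a large change in the read-out. Nothing measured here accounts for the direction or the size of this step, so it stands as an observation only.

One step cannot separate the effect of losing dimethylamino from that of gaining the new arm, nor show how much of the change goes with the chlorine and how much with the rest of that arm. A plain phenoxymethyl group, a simple methoxy group or a carboxylic acid on the same aromatic carbon would each be a further single-place change, and the compounds shown do not say how any of them would read.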